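Adding a Second Chloro to the Anilino Ring

The source may hold more compounds than are shown below. What is called first, only, known or untested is meant among the compounds shown, and "the series" means these compounds.

The three measured compounds, all tested in a functional assay on PC-3 cells (Homo sapiens) for inhibition, read by MTT assay, with a stated time of 72 h; on this read-out lower numbers stand for stronger inhibition and higher numbers for weaker inhibition:
Compound 1 `C#CCSc1nc(Nc2ccc(F)cc2)c2ccncc2n1` gives 17300 nM.
Compound 3 `C#CCSc1nc(Nc2ccc(Cl)cc2)c2ccncc2n1` gives 19000 nM.
Compound 2 `C#CCSc1nc(Nc2ccccc2Cl)c2ccncc2n1` gives only a limit of the assay, > 80000 nM.

For the measured compounds named here, of the two plain numbers, the one for compound 3 is the larger, yet a 1.1-fold higher number from compound 1 to compound 3 (0.04 log units; within the scatter) lies within the scatter, so compound 1 and compound 3 cannot be told apart. The limit for compound 2 is noted as the limit of > 80000 nM in this assay, at which 1 of the 3 values shown sits.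

Compound 4 `C#CCSc1nc(Nc2ccc(Cl)cc2Cl)c2ccncc2n1` differs from compound 3 by chloro in place of hydrogen on an aromatic carbon. Going by the values given here, two measured steps bear on this. Moving the chloro from the 4-position to the 2-position gave an at least 4.2-fold lower number from compound 2 to compound 3 (0.62 log units; beyond the scatter) read backwards, and the related swap gave an at least 4.6-fold higher number from compound 1 to compound 2 (0.66 log units; beyond the scatter); both show that a chloro in the 2-position of this ring comes with a number beyond the scatter and at the limit. Compound 4 keeps the 4-chloro of compound 3 and adds the 2-chloro that marked compound 2, so a higher number is expected in this assay, quite possibly again only a limit. The expected step is a 3.2-fold higher number from compound 3 to compound 4 (0.50 log units; beyond the scatter). Compound 4 is therefore estimated at 60000 nM, with a range from 20000 nM to 160000 nM.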

Compound 4, half-maximal inhibitory concentration: 30400 nM
Compound 4: middle estimate off by 2.0-fold (0.30 log units), on the high side; low and high end bracket the measured number.
By their numbers in this assay, from the lowest: compounds 1, 3 and 4 (each within the scatter of the next). At a limit, above all of these: compound 2.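

In this assay, for the compounds shown here, a chloro ortho to a large group does not by itself push the anilino ring to the limit of the assay, as the earlier compounds alone might have suggested: adding this chloro to the ring that already carries one gives a 1.6-fold higher number from compound 3 to compound 4 (0.20 log units; within the scatter), so the two compounds cannot be told apart. Seen from the other side, placing a further chloro on the ring that holds only the ortho chloro gives an at least 2.6-fold lower number from compound 2 to compound 4 (0.42 log units; beyond the scatter), so the effect of the ortho chloro depends on what else sits on the ring, at least in this small set. Compound 2 remains a limit and not a plain number: the limit of > 80000 nM in this assay, at which 1 of the 4 values shown sits.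

The compounds shown carry only fluoro and chloro groups on this ring, so it stays open whether a methoxy group or an amine in the same place would fit with compound 3 and compound 4 or with compound 2. The values also give no reason why compound 2 stands apart from compound 4, and they cannot tell whether the same holds on other cells.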